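Swapping ethoxy for (methylamino)methyl on compound 2

The source may hold more compounds than are shown below. What is called first, only, known or untested is meant among the compounds shown, and "the series" means these compounds.

The account begins with two measured compounds. Compound 1 `CC[C@H](C)[C@H](N)CN(C(=O)[C@@H]1C[C@H]1c1csc(C)n1)c1ccc(-c2ccccc2)cc1` gives 1500 nM in a functional assay for agonist activity at G protein-coupled receptor 88 (Homo sapiens), read by HTRF and cAMP accumulation; a lower number here means that less compound is needed, a higher number that more compound is needed for the effect. Compound 2 `CCOc1ccc(-c2ccc(N(C[C@@H](N)[C@@H](C)CC)C(=O)[C@@H]3C[C@H]3c3ccccc3)cc2)cc1` gives 90 nM in this assay, the lowest of the two numbers shown; the only other value, that of compound 1, lies at a higher number, and this gap lies beyond the usual scatter.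

The step under study leads from compound 2 to compound 3 `CC[C@H](C)[C@H](N)CN(C(=O)[C@@H]1C[C@H]1c1ccccc1)c1ccc(-c2ccc(CNC)cc2)cc1`, which has not yet been measured in this assay. The two structures differ in one place: (methylamino)methyl in place of ethoxy on an aromatic carbon. For the measured compounds named here, no measured pair differing in only one place is available, so the size of this step has to be estimated from compound 2 alone.

The author expects compound 3 to need somewhat more compound than compound 2 in this assay, a step of a 3.3-fold higher number from compound 2 to compound 3 (0.52 log units; beyond the scatter), a moderate change and not a large one. For compound 3 the estimated value in this assay is 300 nM, with a range from 80 nM to 1200 nM.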

Compound 3, half-maximal effective concentration: 6400 nM
Estimate against measurement, compound 3: 21-fold (1.33 log units) below; measured number outside the range, above it.
By their numbers in this assay, from the lowest: compound 2; then compound 1; then compound 3.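

In this assay, the exchange of ethoxy for (methylamino)methyl gives a 71-fold higher number from compound 2 to compound 3 (1.85 log units; beyond the scatter), a large step and the first one that can be read at this position. It shows that this aromatic carbon, para to a large group, is far from indifferent to what it carries: the two groups hold the same number of heavy atoms, yet the number in this assay moves well beyond the scatter, with the oxygen replaced by a nitrogen and a hydrogen-bond donor entering. Nothing available explains the size of this step.

With a single exchange at this position, the compounds shown leave open whether the rise in the number follows the amine nitrogen, its hydrogen-bond donor, or the placement of the heteroatom one carbon away from the ring, and methoxymethyl, dimethylaminomethyl and aminomethyl groups would help to separate these readings. On these data alone, it also remains open how a longer alkoxy chain or a smaller methoxy group would compare with the ethoxy of compound 2 in this assay.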